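Isoflavone acrylamides: fluoro on the benzyl ring

The source may hold more compounds than are shown below. What is called first, only, known or untested is meant among the compounds shown, and "the series" means these compounds.

Measured so far in a functional assay on Huh-7 cells (Homo sapiens) for inhibition, read by MTT assay, with a stated time of 48 h; on this read-out lower numbers stand for stronger inhibition and higher numbers for weaker inhibition:
compound 1 `O=C(/C=C/c1coc2cc(O)ccc2c1=O)NCc1ccc(F)cc1`: > 100000 nM, a limit of the assay
compound 2 `COc1ccc2c(=O)c(/C=C/C(=O)NCc3ccc(F)cc3)coc2c1`: 21000 nM
compound 3 `O=C(/C=C/c1coc2cc(O)ccc2c1=O)Nc1ccccc1`: 3880 nM

Compound 1 reaches only the limit of > 100000 nM in this assay, at which 1 of the 3 values shown sits, and gives no number. Of the two numbers, compound 2 gives the higher one; compound 3 gives the lower, beyond the scatter. Both measured steps start from compound 1: methylation of the ring hydroxyl gives an at least 4.7-fold lower number from compound 1 to compound 2 (0.67 log units; beyond the scatter), and the exchange of the amide substituent gives an at least 25-fold lower number from compound 1 to compound 3 (1.41 log units; beyond the scatter).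

Compound 4 `COc1ccc2c(=O)c(/C=C/C(=O)NCc3ccc(F)cc3F)coc2c1` differs from compound 2 by a single change: fluoro in place of hydrogen on an aromatic carbon. Among the compounds with values here, no measured step touches the 4-fluorobenzyl group itself; the nearest point of comparison is the exchange at the amide-type nitrogen between compound 1 and compound 3, which replaces the whole group rather than adding to it, so it offers no direct read-across. The added fluoro is small and brings no donor or acceptor, and the shared core and the amide are untouched.

Compound 4 is therefore expected to stay close to compound 2, with no change at the digits printed from compound 2 to compound 4 (within the scatter), that is, no step beyond the scatter in either direction. The estimate for compound 4 is 21000 nM, within 7000 nM to 60000 nM.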

Compound 4, half-maximal inhibitory concentration: > 100000 nM
Compound 4: a limit, no number; the forecaster's own chance of this, stated with the estimate: 8%; middle value at least 4.7-fold (0.67 log units) from the limit.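

In this assay, within the data shown here, a change on the benzyl ring, which no earlier step touched, now proves to matter: fluoro in place of hydrogen on an aromatic carbon, ortho to a large group, gives an at least 4.7-fold higher number from compound 2 to compound 4 (0.67 log units; beyond the scatter). Among these compounds, compound 4 gives > 100000 nM, which is a limit and not a number, so this step has a lower bound only and its true size stays unknown: the limit of > 100000 nM in this assay, at which 2 of the 4 values shown sit. Both earlier steps gave lower numbers, whereas this is the first step to give a higher one, and it comes from adding one fluoro rather than from exchanging the whole amide substituent.

Open, from the compounds shown here alone, is whether this result belongs to fluoro in particular or to any addition at this place, for instance a chloro, a methyl or an amine on the same aromatic carbon of the 4-fluorobenzyl group. Also open, going by these compounds, is whether the same fluoro would have a comparable effect on the phenyl group of compound 3, where the number still lies well inside the measurable range.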